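Hydroxymethyl for trifluoromethoxy on an anilino-quinazolinedione core

This account rests on a few compounds, and the source may have more. Where it says the series, first, only, none or still open, it means among the compounds named here.

Measured so far:
compound 1 `O=C1C(Nc2ccc(OC(F)(F)F)cc2)=CC(=O)c2ncncc21`, 1400 nM
compound 2 `Nc1ccc(-c2ccc(NC3=CC(=O)c4ncncc4C3=O)cc2)cc1`, 2500 nM
compound 3 `O=C1C(NCc2ccc(F)cc2)=CC(=O)c2ncncc21`, 1700 nM

In a functional assay on MIA PaCa-2 cells (Homo sapiens) for cytotoxicity, read by MTT assay, with a stated time of 72 h (on this read-out higher numbers stand for weaker inhibition and lower numbers for stronger inhibition), compound 1 gives the lowest of the three numbers, yet compound 3 sits within the scatter of it, and so does compound 2, so no order among them can be claimed. The step of a 1.8-fold higher number from compound 1 to compound 2 (0.25 log units; within the scatter) shows that swapping the trifluoromethoxy for a larger group at that position left the number within the scatter. Compound 4 `O=C1C(Nc2ccc(CO)cc2)=CC(=O)c2ncncc21` carries the same core with a smaller change: hydroxymethyl in place of trifluoromethoxy on an aromatic carbon. Among the measured compounds shown here, the only measured step at this position bears on it and was small; the data offer nothing on a hydroxymethyl itself. Compound 4 is therefore expected to lie near compound 1, with an estimated step of a 1.4-fold higher number from compound 1 to compound 4 (0.15 log units; within the scatter), and its number in this assay is estimated at 2000 nM, with a range from 900 nM to 4500 nM.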

Compound 4, half-maximal inhibitory concentration: 3500 nM
For compound 4 the middle estimate is 1.8-fold (0.24 log units) below the measured one; the measured number falls inside the stated range.
By their numbers in this assay, from the lowest: compounds 1, 3, 2 and 4 (each within the scatter of the next, the first and the last beyond it).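

In this assay, among the compounds shown here, hydroxymethyl in place of trifluoromethoxy gives a 2.5-fold higher number from compound 1 to compound 4 (0.40 log units; beyond the scatter), the first step at this position to lie beyond the scatter, though only modestly. Hydroxymethyl in place of 4-aminophenyl gives a 1.4-fold higher number from compound 2 to compound 4 (0.15 log units; within the scatter), so those two groups cannot be separated here. Nothing shown accounts for the difference between trifluoromethoxy and hydroxymethyl.

The compounds shown leave open whether a methoxy group, a primary amine or a carboxylic acid at this position would stay close to compound 1 or to compound 4. They also leave open whether a longer chain ending in hydroxyl would differ from hydroxymethyl.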